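The source may report more compounds than this note shows. Statements on the series, on what has been measured and on what is new or still open speak of the compounds shown alone.

In a functional assay on HeLa cells (Homo sapiens) for cytotoxicity, read by cell counting, with a stated time of 4 days (on this read-out higher numbers stand for weaker inhibition and lower numbers for stronger inhibition), compound 1 `C=C(Br)C(=O)Nc1cccc(/C=C2\SC(=O)N(Cc3ccc(C)cc3)C2=O)c1` gives 1200 nM, the lowest of the three numbers in hand. Compound 2 `CC(C)(C)c1ccc(CN2C(=O)S/C(=C\c3ccc(N)cc3)C2=O)cc1` gives 53000 nM and compound 3 `Cc1ccc(CN2C(=O)S/C(=C\c3cccc(N)c3)C2=O)cc1` gives 98000 nM. Among the compounds with values here, the only single-place step, an 82-fold higher number from compound 1 to compound 3 (1.91 log units; beyond the scatter), concerns the group on the nitrogen on an aromatic ring and not the 4-methylphenyl group. Compound 4 `C=C(Br)C(=O)Nc1cccc(/C=C2\SC(=O)N(Cc3ccc(C(F)(F)F)cc3)C2=O)c1` keeps the whole of compound 1 apart from one change: trifluoromethyl in place of methyl on an aromatic carbon. Within the data shown here, no measured pair isolates this change; compounds 2 and 3 differ in more than one place, so their two values alone say nothing about it. With nothing bearing on it, the expected step is no change at the digits printed from compound 1 to compound 4 (within the scatter), none beyond the scatter. Compound 4 is therefore estimated at 1200 nM, with a range from 400 nM to 3600 nM.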

Compound 4, half-maximal inhibitory concentration: 820 nM
The estimate for compound 4 lay 1.5-fold (0.17 log units) above the measured number; low and high end bracket the measured number.
By their numbers in this assay, from the lowest: compounds 4 and 1 (each within the scatter of the next); then compounds 2 and 3 (each within the scatter of the next).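

In this assay, trifluoromethyl in place of methyl gives a 1.5-fold lower number from compound 1 to compound 4 (0.17 log units; within the scatter), so this position accepts the larger group, with four heavy atoms against one, without a shift beyond the scatter. Within the data shown here, this is the first single-place reading on the 4-methylphenyl side; the earlier step concerned only the group on the nitrogen. No available evidence explains the flat result. On these data alone, whether an amine or a carboxylic acid at this aromatic carbon would leave the number equally unchanged remains open.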